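Trimming the sulfonyl substituent: from compound 1 to compound 4

A few compounds are considered here, and "the series" means these few. Any claim that something is new, unique, unknown or untested is made for them only; others in the source may bear on it.

Compound 1 `COCCN(C)S(=O)(=O)c1ccc(C)c(C#Cc2cc(Cl)ccc2OCC(=O)O)c1` is measured in an ADME assay on a cell-free system (plasma, Rattus norvegicus) (a higher number here means a larger unbound share of the compound, a lower number a smaller unbound share), and gives 0.007. Of the two compounds with a number, compound 3 `CS(=O)(=O)c1ccc(F)c(C#Cc2cc(Cl)ccc2OCC(=O)O)c1` is the nearest to it: in this assay compound 3 gives 0.011, and the two numbers lie within the usual scatter of each other, so no order between them can be stated. Compound 2 `Cc1ccc(S(=O)(=O)N2CCCCC2C)cc1C#Cc1cc(Cl)ccc1OCC(=O)O` belongs to the same series, but its result in this assay is reported as not determined, "not determined" (no result reported).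

Compound 4 `Cc1ccc(S(C)(=O)=O)cc1C#Cc1cc(Cl)ccc1OCC(=O)O` has not yet been measured. It differs from compound 1 in one place: methyl in place of (2-methoxyethyl)(methyl)amino on a sulfonyl sulfur. Among the compounds with values here, no step between two measured compounds isolates this change, so its size must be guessed.

Compound 4 is expected to give 0.012 in this assay, with a range of 0.006 to 0.025, because compound 3, which also carries methylsulfonyl on its core, gives 0.011. The expected step of a 1.7-fold higher number from compound 1 to compound 4 (0.23 log units; within the scatter) is a modest rise, near the edge of the scatter.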

Compound 4, unbound fraction: 0.014
Beside the measured number, compound 4's estimate is 1.2-fold (0.07 log units) below it; measured number inside the range.
By their numbers in this assay, from the lowest: compounds 1, 3 and 4 (each within the scatter of the next).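

In this assay, within the data shown here, the first measured change at the sulfonyl sulfur, methyl in place of (2-methoxyethyl)(methyl)amino, gives a step that stays within the scatter (a 2.0-fold higher number from compound 1 to compound 4 (0.30 log units; within the scatter)). Removing the whole chain, with its nitrogen and oxygen, therefore produces no readable shift in unbound fraction in this pair. With methylsulfonyl held constant, methyl in place of fluoro on an aromatic carbon also stays within the scatter (a 1.3-fold higher number from compound 3 to compound 4 (0.10 log units; within the scatter)), and nothing measured here explains the size of either step.

Still open, going by these compounds, is whether a cyclic amine such as morpholine or piperazine on the sulfonyl sulfur would take the unbound fraction beyond the scatter. Also open, on these data alone, is whether chloro or methoxy on that aromatic carbon would do so.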